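Chloro in place of ethynyl: compound 3 to compound 4

The source may report more compounds than this note shows. Statements on the series, on what has been measured and on what is new or still open speak of the compounds shown alone.

Of the compounds shown here, three sharing one core have been measured in a functional assay on HepG2 cells (Homo sapiens) for cytotoxicity, read by MTT assay, with a stated time of 72 h; on this read-out higher numbers stand for weaker inhibition and lower numbers for stronger inhibition. Compound 1 `CN1CCN(c2ccc(Nc3ncc4nc(Nc5ccccc5)n(C5CCCCC5)c4n3)cc2)CC1` gives > 5000 nM, which is a limit of the assay and not a number. Compound 2 `CC(=O)Nc1ccc(Nc2ncc3nc(Nc4ccccc4)n(C4CCCC4)c3n2)cc1` likewise reaches only a limit, > 5000 nM. Within the data shown here, compound 3 `C#Cc1cccc(Nc2nc3cnc(Nc4ccc(N5CCN(C)CC5)cc4)nc3n2C2CCCC2)c1` gives 4900 nM, and this is the only actual number among the three, so it is the sole firm point in the set.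

The next compound to be tested is compound 4 `CN1CCN(c2ccc(Nc3ncc4nc(Nc5cccc(Cl)c5)n(C5CCCC5)c4n3)cc2)CC1`. It keeps the structure of compound 3 except for one place, meta to a large group: chloro in place of ethynyl on an aromatic carbon. In other words, 3-ethynylphenyl becomes 3-chlorophenyl.

Among the measured compounds shown here, no measured pair of compounds shows this change on its own, so the expectation is indirect. It rests first on compound 3, at 4900 nM. It also rests on (the limit of > 5000 nM in this assay, at which 2 of the 3 values shown sit). No shift beyond the usual scatter is expected in this assay, in either direction, and a result reported only as a limit would be no surprise. The expected step is a 1.1-fold higher number from compound 3 to compound 4 (0.05 log units; within the scatter). For compound 4 the estimated value is 5500 nM, with an expected range of 2500 nM to 12000 nM.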

Compound 4, half-maximal inhibitory concentration: 4800 nM
Estimate against measurement, compound 4: 1.1-fold (0.06 log units) above; the measured number falls inside the stated range.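

In this assay, replacing ethynyl with chloro on the aromatic carbon gives a 1.0-fold lower number from compound 3 to compound 4 (0.01 log units; within the scatter). Among these compounds, this is the first reading of a single change at this place, and it exchanges two carbons for one chlorine with no hydrogen-bond donors or acceptors on either side, yet the two groups cannot be told apart on this read-out. The pair also gives the set a second actual number, although the result says little about any change toward higher numbers, as both values stand close to the assay's limit: the limit of > 5000 nM in this assay, at which 2 of the 4 values shown sit.

The compounds shown leave open whether a quite different group at this place, such as an amine or a carboxylic acid, would shift the number beyond the scatter in this assay. With only 3-ethynylphenyl and 3-chlorophenyl compared directly, they also do not show what change, at this place or elsewhere on the shared core, would bring a clearly lower number.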